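Swapping butyl for tert-butyl on an aromatic carbon

The source may report more compounds than this note shows. Statements on the series, on what has been measured and on what is new or still open speak of the compounds shown alone.

All three values below come from a functional assay on MCF7 cells (Homo sapiens) for antiproliferative activity, read by MTT assay, with a stated time of 72 h (on this read-out higher numbers stand for weaker inhibition and lower numbers for stronger inhibition), and are compared on that scale.

Compound 1 `O=C1O[C@H]([C@@H](O)Cn2cc(-c3cc(C(F)(F)F)cc(C(F)(F)F)c3)nn2)C(OCc2ccccc2)=C1OCc1ccccc1` gives 45900 nM
Compound 2 `CCCCc1cn(C[C@H](O)[C@H]2OC(=O)C(OCc3ccccc3)=C2OCc2ccccc2)nn1` gives 7910 nM
Compound 3 `O=C1O/C(=C\Cn2cc(-c3cc(C(F)(F)F)cc(C(F)(F)F)c3)nn2)C(OCc2ccccc2)=C1OCc1ccccc1` gives > 100000 nM as a limit of the assay and not a number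

Only two of these results are actual numbers, and a lower number means stronger inhibition. Compound 2 gives 7910 nM as the lower of the two. Compound 1 gives 45900 nM as the higher, and the gap between them lies beyond the usual scatter.

The next molecule is compound 4 `CC(C)(C)c1cn(C[C@H](O)[C@H]2OC(=O)C(OCc3ccccc3)=C2OCc2ccccc2)nn1`, which has not yet been measured. It differs from compound 2 in one place: tert-butyl in place of butyl on an aromatic carbon. Tert-butyl stands in place of butyl on an aromatic carbon of a five-membered aromatic ring with 3 nitrogen. The two compounds have the same atoms, joined differently.

For the measured compounds named here, no two measured compounds differ in only one place, so the data offer no direct guide to the size of this change. Starting from compound 2 at 7910 nM in this assay, only a small rise in the number is expected, with no step beyond the scatter. The expected change is a 1.5-fold higher number from compound 2 to compound 4 (0.18 log units; within the scatter). For compound 4 the estimated value is 12000 nM, with an expected range from 4000 nM to 40000 nM.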

Compound 4, half-maximal inhibitory concentration: 730 nM
For compound 4 the middle estimate is 16-fold (1.22 log units) above the measured one; the whole stated range lies above it.
By their numbers in this assay, from the lowest: compound 4; then compound 2; then compound 1. At a limit, above all of these: compound 3.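

In this assay, for the compounds shown here, this is the first pair that differs in only one place, and that single change has a large effect: an 11-fold lower number from compound 2 to compound 4 (1.03 log units; beyond the scatter). The butyl and tert-butyl groups each hold 4 carbon atoms, and the two compounds have the same atoms overall, so the step comes from how those carbons are joined and not from how many there are. This position, on an aromatic carbon of the five-membered aromatic ring with 3 nitrogen, therefore responds strongly to the shape of the chain attached to it, though nothing measured here gives the reason for that response.

One pair cannot show whether branching in general lowers the number or whether tert-butyl is a special case, and groups such as isopropyl, cyclohexyl or a longer branched chain at the same carbon would help separate those two readings. On these data alone, it also remains open whether a polar group at this carbon, such as an amine or a carboxylic acid, would keep any of this gain.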